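A few compounds are considered here, and "the series" means these few. Any claim that something is new, unique, unknown or untested is made for them only; others in the source may bear on it.

In an ADME assay on cells (Peritoneal macrophage, Mus musculus, strain Balb/c) for cytotoxicity, read by resazurin assay, with a stated time of 72 h (a higher number here means that more compound is tolerated, a lower number that less compound is tolerated), compound 1 `CC1(Cc2ccc(/C(N)=N/O)cc2)CC(S(=O)(=O)c2ccc(F)cc2)=C(c2ccc(/C(N)=N/O)cc2)O1` gives 42200 nM. Compound 2 `Cc1ccc(CC2(C)CC(S(=O)(=O)c3ccc(F)cc3)=C(c3ccc(/C(N)=N/O)cc3)O2)cc1` gives 54400 nM, level with compound 1 within the scatter. Compound 3 `Cc1cccc(CC2(C)CC(S(=O)(=O)c3ccc(F)cc3)=C(c3ccc(/C(N)=N/O)cc3)O2)c1` differs from compound 2 as follows: 3-methylphenyl in place of 4-methylphenyl on a saturated chain carbon bound to a saturated ring carbon. In words, 3-methylphenyl stands in place of 4-methylphenyl on a saturated chain carbon bound to a saturated ring carbon. Among the compounds with values here, the one measured step, a 1.3-fold higher number from compound 1 to compound 2 (0.11 log units; within the scatter), lies on an aromatic carbon and does not test this change, yet it gives no ground to expect a step beyond the scatter in this assay. The expected step is a 1.0-fold lower number from compound 2 to compound 3 (0.02 log units; within the scatter). For compound 3 the estimated value is 52000 nM, with an expected range of 25000 nM to 100000 nM.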

Compound 3, half-maximal cytotoxic concentration: 112000 nM
Beside the measured number, compound 3's estimate is 2.2-fold (0.33 log units) below it; measured number outside the range, above it.
By their numbers in this assay, from the lowest: compounds 1 and 2 (each within the scatter of the next); then compound 3.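

In this assay this position, on a saturated chain carbon bound to a saturated ring carbon, responds to 3-methylphenyl in place of 4-methylphenyl: the same atoms, joined differently, give a 2.1-fold higher number from compound 2 to compound 3 (0.31 log units; beyond the scatter) and so a step beyond the scatter, which the aromatic-carbon change did not produce. The change at this same position also gives a 2.7-fold higher number from compound 1 to compound 3 (0.42 log units; beyond the scatter) as a modest step. No available data explain either step.

From the compounds shown here alone, whether the step holds with an ethyl, a methoxy or an amine in place of the methyl remains open, as does the effect of a longer chain at this position.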